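The source may report more compounds than this note shows. Statements on the series, on what has been measured and on what is new or still open speak of the compounds shown alone.

Of the compounds shown here, three built on one shared core have been tested in a functional assay on MCF7 cells (Homo sapiens) for antiproliferative activity, read by MTT assay, with a stated time of 24 h; a lower number here means a stronger inhibitor, a higher number a weaker inhibitor. Compound 1 `CCn1c(C(=O)N[C@@H](C)C(=O)OC)ccc1C(CC)(CC)c1ccc(OCS(=O)(=O)c2ccccc2)c(C)c1` gives 43700 nM. Compound 3 `CCn1c(C(=O)N[C@@H](C)CO)ccc1C(CC)(CC)c1ccc(OCS(=O)(=O)c2ccccc2)c(C)c1` gives 10800 nM. Compound 2 `CCn1c(C(=O)N[C@@H](CC(=O)OC)C(=O)OC)ccc1C(CC)(CC)c1ccc(OCS(=O)(=O)c2ccccc2)c(C)c1` reaches only the limit of the assay, > 50000 nM, which is the limit of > 50000 nM in this assay, at which 1 of the 3 values shown sits, so for compound 2 there is no number. On the numbers shown, compound 2 and compound 1 cannot be separated, since an at least 1.1-fold higher number from compound 1 to compound 2 (0.05 log units; that floor lies within the scatter), whereas compound 3 sits clearly lower.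

Compound 4 `CCn1c(C(=O)N[C@@H](CO)CCO)ccc1C(CC)(CC)c1ccc(OCS(=O)(=O)c2ccccc2)c(C)c1` has not yet been measured; it differs from compound 2 in one place: 3-hydroxy-1-(hydroxymethyl)propyl in place of 1,2-bis(methoxycarbonyl)ethyl on an amide-type nitrogen. Among the measured compounds shown here, two measured steps bear on this. The related exchange of 1-(hydroxymethyl)ethyl for 1,2-bis(methoxycarbonyl)ethyl gave an at least 4.6-fold lower number from compound 2 to compound 3 (0.66 log units; beyond the scatter), and the smaller exchange of hydroxymethyl for methoxycarbonyl gave a 4.0-fold lower number from compound 1 to compound 3 (0.61 log units; beyond the scatter). Compound 4 likewise loses both ester groups and carries hydroxyl groups instead, so a fall of similar size is expected, giving an at least 3.3-fold lower number from compound 2 to compound 4 (0.52 log units; beyond the scatter). The estimate for compound 4 in this assay is therefore 15000 nM, expected to lie between 5000 nM and 50000 nM.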

Compound 4, half-maximal inhibitory concentration: 27400 nM
The estimate for compound 4 lay 1.8-fold (0.26 log units) below the measured number, within the range that was stated.
By their numbers in this assay, from the lowest: compound 3; then compounds 4 and 1 (each within the scatter of the next). At a limit, above all of these: compound 2.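

In this assay, hydroxyl groups on the amide-type nitrogen do not by themselves reach the level of compound 3, with a 2.5-fold higher number from compound 3 to compound 4 (0.40 log units; beyond the scatter) when 3-hydroxy-1-(hydroxymethyl)propyl replaces 1-(hydroxymethyl)ethyl, while replacing 1-(methoxycarbonyl)ethyl gives a 1.6-fold lower number from compound 1 to compound 4 (0.20 log units; within the scatter) and so no separable change. Removing both ester groups of compound 2 gives an at least 1.8-fold lower number from compound 2 to compound 4 (0.26 log units; that floor lies within the scatter), which is only a floor and does not show a real gain. Compound 2 has no exact value: the limit of > 50000 nM in this assay, at which 1 of the 4 values shown sits.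

From the compounds shown here alone, it remains open whether the higher number for compound 4 follows from the longer chain or from its added hydroxyl group, as a simple 3-hydroxypropyl group on the same nitrogen might begin to separate the two. It is also unknown how an amine or a carboxylic acid in place of these hydroxyl groups would behave.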